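The compounds below may be only part of what the source reports. "The series", "measured", "known", "first", "only" and "open" are said of these compounds alone.

Measured in a functional assay on U-87MG ATCC cells (Homo sapiens) for inhibition; a lower number here means a stronger inhibitor, a higher number a weaker inhibitor:
- Compound 1 `COc1cc(/C=C/C(=O)c2cccc(NC(=O)c3ccc(Cl)cc3)c2)ccc1O`: > 50 ug/mL, a limit
- Compound 2 `COc1cc(/C=C/C(=O)c2cccc(NC(=O)c3ccc(Cl)cc3Cl)c2)ccc1O`: > 50 ug/mL, a limit

Compound 2 stands only at a limit, > 50 ug/mL, and has no exact number. What the data show is the limit of > 50 ug/mL in this assay, at which 2 of the 2 values shown sit. Among the measured compounds shown here, the one measured step is a step that the two limits leave unreadable from compound 1 to compound 2. Compound 3 `CCOC(=O)C(=O)Nc1cccc(C(=O)/C=C/c2ccc(O)c(OC)c2)c1` differs from compound 2 as follows: ethoxycarbonyl in place of 2,4-dichlorophenyl on a carbonyl carbon. The measured step concerns a different change and has no readable size, so it offers no basis for expecting a step beyond the scatter in either direction. The expected step is a step that the limit leaves unreadable from compound 2 to compound 3. The estimate for compound 3 is 55 ug/mL, with an expected range from 25 ug/mL to 120 ug/mL.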

Compound 3, half-maximal inhibitory concentration: > 50 ug/mL
Compound 3 was reported as a limit (the forecaster's own chance of this, stated with the estimate: 75%); the middle value does not contradict the limit.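

Compound 3 gives > 50 ug/mL, which is a limit. The steps linking compound 1, compound 2 and compound 3 therefore cannot be read: the limit of > 50 ug/mL in this assay, at which 3 of the 3 values shown sit.

From the compounds shown here alone, how strongly any of these three compounds inhibits in this assay, and whether exchanging these groups changes it, stays open.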